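Hydroxy on the benzyl group of compound 3

This account rests on a few compounds, and the source may have more. Where it says the series, first, only, none or still open, it means among the compounds named here.

Values in a functional assay on HeLa cells (Homo sapiens) for inhibition, read by CCK-8 assay, with a stated time of 48 h; a higher number here means a weaker inhibitor, a lower number a stronger inhibitor:
- compound 1 `O=S(=O)(NCCNC(=S)Nc1cccc(Cl)c1)c1ccc(-c2ccccc2OCc2cccc(O)c2)s1`: 10700 nM
- compound 2 `O=C(NCCNS(=O)(=O)c1ccc(-c2ccccc2OCc2cccc(O)c2)s1)Nc1cc(Cl)cc(Cl)c1`: > 50000 nM (a limit, not a number)
- compound 3 `O=[N+]([O-])c1cccc(NC(=S)NCCNS(=O)(=O)c2ccc(-c3ccccc3OCc3ccccc3)s2)c1`: 12800 nM

In this assay compound 3 gives 12800 nM, within the scatter of compound 1 at 10700 nM. The only other measured entry is the limit for compound 2.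

Compound 4 `O=[N+]([O-])c1cccc(NC(=S)NCCNS(=O)(=O)c2ccc(-c3ccccc3OCc3cccc(O)c3)s2)c1` arises from compound 3 by a single change, hydroxy in place of hydrogen on an aromatic carbon, so that benzyloxy becomes (3-hydroxybenzyl)oxy.

Among the compounds with values here, the one measured step, an at least 4.6-fold higher number from compound 1 to compound 2 (0.66 log units; beyond the scatter), is a change on an amine nitrogen, and both of its compounds already carry the (3-hydroxybenzyl)oxy group. Within the data shown here, it therefore gives no size for the hydroxy change, and no measured step isolates that change. Compound 1 does show that a compound with this group can give a number, 10700 nM, close to that of compound 3. From the compounds shown here alone, on that basis, no step beyond the scatter is expected in this assay, and the direction stays open. The expected step is a 1.2-fold lower number from compound 3 to compound 4 (0.07 log units; within the scatter). For compound 4 the estimated value is 11000 nM, with an expected range from 4500 nM to 28000 nM.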

Compound 4, half-maximal inhibitory concentration: 11100 nM
Estimate against measurement, compound 4: 1.0-fold (0.00 log units) below, and the stated range covers the measured number.
By their numbers in this assay, from the lowest: compounds 1, 4 and 3 (each within the scatter of the next). At a limit, above all of these: compound 2.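

In this assay, within the data shown here, the step for hydroxy in place of hydrogen on an aromatic carbon, a 1.2-fold lower number from compound 3 to compound 4 (0.06 log units; within the scatter), gives the first direct reading of this change, and benzyloxy and (3-hydroxybenzyl)oxy are not told apart here. With the (3-hydroxybenzyl)oxy group in place, nitro in place of chloro on an aromatic carbon, a 1.0-fold higher number from compound 1 to compound 4 (0.02 log units; within the scatter), is also within the scatter, so this pair does not separate those two groups either. The only step beyond the scatter involving compound 4 lies on the amine nitrogen, an at least 4.5-fold lower number from compound 2 to compound 4 (0.65 log units; beyond the scatter), and it starts from compound 2, whose entry is a limit and not a number: the limit of > 50000 nM in this assay, at which 1 of the 4 values shown sits.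

From the compounds shown here alone, whether a methoxy group, an amine or a carboxylic acid on the same aromatic carbon would also stay within the scatter remains open, as does the size of the hydroxy change when other groups sit on the amine nitrogen. The groups in compound 2 and compound 4 differ in more than one feature, so the part played by the oxygen and sulfur atoms cannot be separated from that of the substituents on the aromatic ring.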